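The compounds below may be only part of what the source reports. "The series", "measured", "known", "first", "only" and "open" are said of these compounds alone.

Three esters sharing one core have been measured in a functional assay on DU-145 cells (Homo sapiens) for cytotoxicity, read by MTT assay; on this read-out higher numbers stand for weaker inhibition and lower numbers for stronger inhibition: compound 1 (`CCCCC(O)CC(=O)O[C@H](CC=C(C)C)C1=CC(=O)c2c(O)ccc(O)c2C1=O`) gives 45300 nM, compound 2 (`CC[C@@](C)(O)CC(=O)O[C@H](CC=C(C)C)C1=CC(=O)c2c(O)ccc(O)c2C1=O`) gives 12700 nM and compound 3 (`CC(C)=CC[C@@H](OC(=O)C1CCCCO1)C1=CC(=O)c2c(O)ccc(O)c2C1=O`) gives 24700 nM. Compound 3 holds the middle number of the three, yet it lies within the scatter of both others.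

The next compound is compound 4 (`CC(C)=CC[C@@H](OC(=O)c1ccoc1)C1=CC(=O)c2c(O)ccc(O)c2C1=O`), and the change is furan-3-yl in place of oxan-2-yl on a carbonyl carbon. A five-membered aromatic ring replaces a six-membered non-aromatic ring on the same carbonyl carbon.

Two measured steps alter the group on this carbonyl carbon: a 1.8-fold lower number from compound 1 to compound 3 (0.26 log units; within the scatter) and a 1.9-fold higher number from compound 2 to compound 3 (0.29 log units; within the scatter). Both stay within the scatter, although neither brings in an aromatic ring. The largest step seen, a 3.6-fold lower number from compound 1 to compound 2 (0.55 log units; beyond the scatter), is modest and changes only the hydroxy-bearing chain. Among the compounds with values here, no measured compound carries a furan-3-yl group, so these steps offer only indirect guidance, and the range must stay wide.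

On this evidence, no step beyond the scatter is expected in this assay. The expected step is a 1.4-fold lower number from compound 3 to compound 4 (0.14 log units; within the scatter), and its direction is tentative. For compound 4 the estimated value is 18000 nM, with an expected range from 6000 nM to 50000 nM.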

Compound 4, half-maximal inhibitory concentration: > 100000 nM
Compound 4 was reported as a limit (the forecaster's own chance of this, stated with the estimate: 5%); at least 5.5-fold (0.74 log units) between middle value and limit.
By their numbers in this assay, from the lowest: compounds 2, 3 and 1 (each within the scatter of the next, the first and the last beyond it). At a limit, above all of these: compound 4.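

In this assay compound 4 is reported only as a limit, and it is the only compound shown at that limit: the limit of > 100000 nM in this assay, at which 1 of the 4 values shown sits. Even read as bounds, the new steps all lie beyond the scatter: an at least 4.0-fold higher number from compound 3 to compound 4 (0.60 log units; beyond the scatter), an at least 7.8-fold higher number from compound 2 to compound 4 (0.89 log units; beyond the scatter) and an at least 2.2-fold higher number from compound 1 to compound 4 (0.34 log units; beyond the scatter). So the group on this carbonyl carbon can shift the number well beyond what the earlier steps involving oxan-2-yl showed, even though oxan-2-yl and furan-3-yl have the same hetero atom, donor and acceptor counts and no net charge, and differ in ring size and aromatic character.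

On these data alone, how far compound 4 lies past its limit stays open, as does whether the loss follows the aromatic ring, the five-membered ring or furan-3-yl alone. An oxolan-3-yl group, a phenyl group or furan-2-yl on this same carbonyl carbon would begin to separate these readings, and the compounds shown contain none of these groups.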